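Extending the Chain: 3-bromopropyl to 4-bromobutyl

The compounds below may be only part of what the source reports. "The series", "measured", "known", "first", "only" and "open" are said of these compounds alone.

In a functional assay on A2780 cells (Homo sapiens) for antiproliferative activity, read by sulforhodamine B assay, with a stated time of 96 h (a higher number here means a weaker inhibitor, a lower number a stronger inhibitor), compound 1 `C/C(=C\CC/C(C)=C/CC[C@@H]1[C@@]2(C)CCC(=O)C(C)(C)[C@@H]2CC[C@@]1(C)O)CC/C=C(\C)C(=O)OCCBr` reaches only a limit of the assay, > 30000 nM. Going by the values given here, compound 2 `C/C(=C\CC/C(C)=C/CC[C@@H]1[C@@]2(C)CCC(=O)C(C)(C)[C@@H]2CC[C@@]1(C)O)CC/C=C(\C)C(=O)OCCCBr` gives 18100 nM, the only true number so far. Compound 3 `C/C(=C\CC/C(C)=C/CC[C@@H]1[C@@]2(C)CCC(=O)C(C)(C)[C@@H]2CC[C@@]1(C)O)CC/C=C(\C)C(=O)OCCCCBr` differs from it by bromomethyl in place of bromo on a saturated chain carbon, three bonds along the chain from an oxygen next to a carbonyl group. Among the compounds with values here, one measured step bears on this, the same replacement two bonds along: an at least 1.6-fold lower number from compound 1 to compound 2 (0.21 log units; that floor lies within the scatter), a floor within the scatter. The expected change is therefore small, a 1.3-fold lower number from compound 2 to compound 3 (0.11 log units; within the scatter) in this assay, not beyond the scatter. For compound 3 the estimated value is 14000 nM, with an expected range of 6000 nM to 30000 nM.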

Compound 3, half-maximal inhibitory concentration: 21600 nM
Compound 3: middle estimate off by 1.5-fold (0.19 log units), on the low side; the range from low to high includes it.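

In this assay, the further extension to 4-bromobutyl shows that at this place, three bonds along the chain from an oxygen next to a carbonyl group, the added carbon moves the number by no more than the scatter (a 1.2-fold higher number from compound 2 to compound 3 (0.08 log units; within the scatter)). Going by these compounds alone, this gives the first comparison between two true numbers, and they stand level, while the comparison with the bromoethyl ester gives only a floor (an at least 1.3-fold lower number from compound 1 to compound 3 (0.14 log units; that floor lies within the scatter)). As far as these compounds go, whether a longer chain, or an amine or a carboxylic acid in place of the bromo, would move the number beyond the scatter stays open. The true size of any step from compound 1 also stays open because compound 1 stands at a limit of the assay: the limit of > 30000 nM in this assay, at which 1 of the 3 values shown sits.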